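The source may report more compounds than this note shows. Statements on the series, on what has been measured and on what is new or still open speak of the compounds shown alone.

Measured compounds:
compound 1 `COc1cc2c(cc1OC)C(CC(=O)O)CC2` — 18.8%
compound 2 `COc1cc2c(cc1OC)C(CC(N)=O)CC2` — 18.8%
compound 3 `COc1cc2c(cc1OC)C(CC(=O)N(C)C)CC2` — 25%

All three share one core and differ only at the carbonyl carbon of the side chain. In a functional assay on the whole organism (strain Wistar) for inhibition, with Rattus norvegicus as the target, read by paw edema, with stated times of 60 min and 1 h, at a dose of 100 mg/kg by the oral route (on this read-out lower numbers stand for less inhibition and higher numbers for more inhibition at the one dose given (going by the name of the read-out)), compound 1 gives 18.8%. In this assay compound 2 gives 18.8%, and in this assay compound 3 gives 25%. Compound 3 is the reference here: a number 6.2 percentage points higher from compound 1 to compound 3 (within the scatter) and a number 6.2 percentage points higher from compound 2 to compound 3 (within the scatter), so its number sits within the scatter of both others, and no change at the digits printed from compound 1 to compound 2 (within the scatter). Nothing among the three separates the hydroxy, amino and dimethylamino groups at this carbonyl carbon.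

Compound 4 `COc1cc2c(cc1OC)C(CC(=O)NC(C)C)CC2` is the next compound, not yet measured. It differs from compound 3 as follows: isopropylamino in place of dimethylamino on a carbonyl carbon. For the measured compounds named here, the steps that bear on this change are those of compound 1 and compound 2 to compound 3, each a replacement at the same carbonyl carbon, and each stayed within the scatter. On that basis no step beyond the scatter is expected in this assay for compound 4; no change at the digits printed from compound 3 to compound 4 (within the scatter) is the expected step. Compound 4 is therefore estimated at 25% in this assay, with a range from 10% to 40%.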

Compound 4, a percentage reported as inhibition, in the whole organism at one dose (the size of the read-out at that dose, not a potency): 31.3%
The estimate for compound 4 lay 6.3 percentage points below the measured number; the measured number falls inside the stated range.
By their numbers in this assay, from the lowest: compounds 1, 2, 3 and 4 (each within the scatter of the next, the first and the last beyond it).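

In this assay, for the compounds shown here, isopropylamino is the first group at this carbonyl carbon to give a step beyond the scatter, both against the primary amide (a number 12.5 percentage points higher from compound 2 to compound 4 (beyond the scatter)) and against the acid (a number 12.5 percentage points higher from compound 1 to compound 4 (beyond the scatter)). The change from dimethylamino to isopropylamino does not separate the two substituted amides (a number 6.3 percentage points higher from compound 3 to compound 4 (within the scatter)), so compound 3 remains within the scatter of all three other compounds, and only compound 4 stands apart from compound 1 and compound 2. No accompanying measurement bears on why the isopropyl group on the amide-type nitrogen gives this difference.

The compounds shown leave open whether a longer chain on that nitrogen, such as n-butyl, or a cyclohexyl or benzyl group would extend the step seen in this assay or leave it within the scatter. They also leave open how a methyl ester or a ring amine such as piperidine or morpholine at the same carbonyl carbon would compare with the isopropylamino group of compound 4.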